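Fluorine on the Phenyl Ring of a Boron-Containing Enone

The source may hold more compounds than are shown below. What is called first, only, known or untested is meant among the compounds shown, and "the series" means these compounds.

Compound 1 `O=C(/C=C/c1ccc2c(c1)B(O)OC2)c1ccccc1` is the anchor of this comparison. Among the compounds with values here, in a functional assay on HCT-116 cells (Homo sapiens) for cytotoxicity, read by MTT assay, with a stated time of 48 h (on this read-out lower numbers stand for stronger inhibition and higher numbers for weaker inhibition), compound 1 gives 6100 nM, the lowest of the two numbers measured so far. Compound 2 `Nc1ccc(C(=O)/C=C/c2ccc3c(c2)B(O)OC3)cc1`, which carries an amino in place of hydrogen on an aromatic carbon, gives 26100 nM in this assay, a step of a 4.3-fold higher number from compound 1 to compound 2 (0.63 log units; beyond the scatter).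

Compound 3 `O=C(/C=C/c1ccc2c(c1)B(O)OC2)c1cccc(F)c1` differs from compound 1 by fluoro in place of hydrogen on an aromatic carbon. Within the data shown here, the only measured step that touches the same phenyl ring is the one from compound 1 to compound 2, and it was modest. Fluoro is a different group from amino, so that step is only a loose guide; the expectation for compound 3 is a step in this assay no larger than the scatter, perhaps a slightly higher number, a 1.1-fold higher number from compound 1 to compound 3 (0.06 log units; within the scatter). Compound 3 is therefore estimated at 7000 nM, with a range from 3000 nM to 16000 nM.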

Compound 3, half-maximal inhibitory concentration: 6700 nM
Estimate against measurement, compound 3: 1.0-fold (0.02 log units) above; low and high end bracket the measured number.
By their numbers in this assay, from the lowest: compounds 1 and 3 (each within the scatter of the next); then compound 2.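

Fluoro on a carbon of the phenyl ring, meta to a large group, gives a step within the scatter in this assay (a 1.1-fold higher number from compound 1 to compound 3 (0.04 log units; within the scatter)), so this single small change leaves the result of the core of compound 1 unshifted, in contrast to the amino change. Set against the amino compound, the step is beyond the scatter (a 3.9-fold lower number from compound 2 to compound 3 (0.59 log units; beyond the scatter)), but the group and its place on the ring both differ in that pair, so the two effects cannot be separated. Nothing measured here accounts for either step.

On these data alone, it remains open whether a larger group at the same place, such as methoxy or trifluoromethyl, would also stay within the scatter. A 4-fluorophenyl or 3-aminophenyl compound would show whether the group or its place matters more.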